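The compounds below may be only part of what the source reports. "The series", "measured", "known", "first", "only" and "open" are said of these compounds alone.

Compound 3 `CC(C)n1ncnc1-c1ccccc1NCC1=NCCN1` stands second highest of the three numbers in a functional assay with Alpha-1D adrenergic receptor (Homo sapiens) as the target, read by calcium flux (on this read-out lower numbers stand for smaller maximal responses and higher numbers for larger maximal responses), where compound 3 gives 37%; compound 2 `CCn1ncnc1-c1ccccc1NCC1=NCCN1` gives 55%, and compound 1 `Cc1nc(-c2ccccc2NCC2=NCCN2)n(C)n1` gives 0%. Compound 4 `CCCCn1ncnc1-c1ccccc1NCC1=NCCN1` differs from compound 3 by butyl in place of isopropyl on an aromatic nitrogen. Within the data shown here, only one measured step bears on this, the change of methyl in place of hydrogen on a saturated chain carbon bound to an aromatic nitrogen and a saturated chain carbon, which was a number 18 percentage points lower from compound 2 to compound 3 (beyond the scatter). Enlarging the group on the aromatic nitrogen there lowered the maximal response modestly; butyl is longer but straight, so a small step in either direction, or none beyond the scatter, is expected. Compound 4 is estimated at 35%, within a range from 15% to 55%. This corresponds to an expected step of a number 2 percentage points lower from compound 3 to compound 4 (within the scatter) in this assay.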

Compound 4, largest response reached (reported as maximal response), in percent of the reference or control that the assay uses: 66%
For compound 4 the middle estimate is 31 percentage points below the measured one, and the stated range ends below it.
By their numbers in this assay, from the lowest: compound 1; then compound 3; then compound 2; then compound 4.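

At this aromatic nitrogen, a larger group does not always mean a smaller maximal response: butyl in place of isopropyl gives a number 29 percentage points higher from compound 3 to compound 4 (beyond the scatter) in this assay and so reverses the fall seen with isopropyl. The straight butyl chain also goes past ethyl, with a number 11 percentage points higher from compound 2 to compound 4 (beyond the scatter) as the step between those two compounds. Nothing available here explains this reversal.

From the compounds shown here alone, whether the response keeps rising with a longer chain such as hexyl stays open. So does whether a branched butyl group such as tert-butyl falls as isopropyl did.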